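The source may report more compounds than this note shows. Statements on the series, on what has been measured and on what is new or still open speak of the compounds shown alone.

In a functional assay on DU-145 cells (Homo sapiens) for antiproliferative activity, read by MTT assay, with a stated time of 72 h (a higher number here means a weaker inhibitor, a lower number a stronger inhibitor), compound 1 `Cc1cccc(N(C)S(=O)(=O)C2CC3OC2C(c2ccc(NC(=O)CCCCCCC(=O)O)cc2)=C3c2ccc(O)cc2)c1` reads > 100000 nM, which is a limit of the assay and not a number. Compound 2 `COc1cccc(N(C)S(=O)(=O)C2CC3OC2C(c2ccc(NC(=O)CCCCCCC(=O)O)cc2)=C3c2ccc(O)cc2)c1` gives 62200 nM, and compound 3 `CN(c1cccc2ccccc12)S(=O)(=O)C1CC2OC1C(c1ccc(NC(=O)CCCCCCC(=O)O)cc1)=C2c1ccc(O)cc1` gives 70900 nM. Compound 3 therefore stands with compound 2, with a 1.1-fold higher number from compound 2 to compound 3 (0.06 log units; within the scatter), and the two cannot be told apart. Compound 4 `CCN(c1ccccc1)S(=O)(=O)C1CC2OC1C(c1ccc(NC(=O)CCCCCCC(=O)O)cc1)=C2c1ccc(O)cc1` carries ethyl(phenyl)amino in place of methyl(naphthalen-1-yl)amino on a sulfonyl sulfur. The nearest measured changes are those of the aromatic group on the sulfonamide nitrogen. These are an at least 1.4-fold lower number from compound 1 to compound 3 (0.14 log units; that floor lies within the scatter) and a 1.1-fold higher number from compound 2 to compound 3 (0.06 log units; within the scatter), and neither shows a step beyond the scatter. Within the data shown here, none of the measured compounds varies the methyl on that nitrogen, so the ethyl group remains untested in this assay. Across these changes, compound 2 and compound 3 both stay close to the limit seen for compound 1, so no step beyond the scatter is expected here. The expected change is a 1.2-fold higher number from compound 3 to compound 4 (0.08 log units; within the scatter). For compound 4 the estimated value is 85000 nM, with an expected range from 45000 nM to 160000 nM.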

Compound 4, half-maximal inhibitory concentration: > 100000 nM
Compound 4 ended at the assay's limit; the forecaster's own chance of this, stated with the estimate: 35%; middle value at least 1.1-fold (0.07 log units) from the limit.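

In this assay compound 4 gives > 100000 nM, which is a limit of the assay and not a number. Replacing the earlier aromatic groups on the sulfonamide nitrogen with ethyl(phenyl)amino gives an at least 1.4-fold higher number from compound 3 to compound 4 (0.14 log units; that floor lies within the scatter) and an at least 1.6-fold higher number from compound 2 to compound 4 (0.20 log units; that floor lies within the scatter), so the change brings no measurable gain, while a real loss remains unproven. The step linking compound 1 and compound 4 cannot be read, and a second, differently substituted sulfonamide now sits at the same ceiling: the limit of > 100000 nM in this assay, at which 2 of the 4 values shown sit.

Compound 4 alters both the alkyl group and the aromatic group, so the effect of ethyl alone stays unresolved; a methyl(phenyl)amino group would separate the two. As far as these compounds go, it also remains open whether an amine or a carboxylic acid on the phenyl ring would bring such compounds clear of the limit.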